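Swapping Chloro for Methoxy on a Phenyl Ring

The source may report more compounds than this note shows. Statements on the series, on what has been measured and on what is new or still open speak of the compounds shown alone.

- compound 1 `COCCn1c(-c2ccccc2Cl)nc2c(N3CCN(C(C)=O)CC3)nc(C)nc21`: 35%
- compound 2 `Cc1nc(N2CCN(C)CC2)c2nc(-c3ccccc3Cl)n(CCN3CCCC3=O)c2n1`: 13%
- compound 3 `Cc1nc(N2CCN(C)CC2)c2nc(-c3cccc(Cl)c3)n(C3CCOCC3)c2n1`: 25%

In an ADME assay (liver) for metabolic stability, with Liver microsome (Homo sapiens) as the target, read by LC-MS, using microsomes, with a stated time of 30 min, tested at 4 uM (on this read-out lower numbers stand for a less stable compound and higher numbers for a more stable compound), compound 3 gives 25%. Compound 1 gives 35%, and compound 2 gives 13%. The gap between compound 3 and compound 1 lies within the usual scatter. The gap between compound 3 and compound 2 lies beyond the usual scatter, with compound 2 the lower of the two.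

Compound 4 `COc1cccc(-c2nc3c(N4CCN(C)CC4)nc(C)nc3n2C2CCOCC2)c1` differs from compound 3 in one place: methoxy in place of chloro on an aromatic carbon, with methoxy in place of chloro on an aromatic carbon. Among the compounds with values here, no measured pair of compounds shows what this swap does in this assay. The expected change is a number 5 percentage points lower from compound 3 to compound 4 (within the scatter), a small downward step that is not expected to go beyond the scatter. For compound 4 the estimated value is 20%, with an expected range from 7% to 36%.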

Compound 4, percent of the compound remaining: 40%
Compound 4: the middle estimate sits 20 percentage points below what was measured; measured number above the stated range.
By their numbers in this assay, from the lowest: compound 2; then compounds 3, 1 and 4 (each within the scatter of the next, the first and the last beyond it).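

In this assay, replacing chloro with methoxy on this aromatic carbon gives a number 15 percentage points higher from compound 3 to compound 4 (beyond the scatter). This is the first one-place comparison among these compounds, and it shows that the group at this position can change how much compound remains, with 3-methoxyphenyl giving the more stable result here. Nothing measured here explains the rise.

From the compounds shown here alone, it remains open whether a longer chain such as ethoxy, or an amine such as dimethylamino, would do the same at this position. The same swap on compound 1 or compound 2 also remains untested in the compounds shown.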